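One Substituent Swap in a Weakly Active Pair

A few compounds are considered here, and "the series" means these few. Any claim that something is new, unique, unknown or untested is made for them only; others in the source may bear on it.

Compound 1, `CC(C)n1ncc2c(C(=O)NC3CCCC3)cccc21`, in a functional assay on PC-3 cells (Homo sapiens) for inhibition, read by MTT assay, with a stated time of 72 h (on this read-out lower numbers stand for stronger inhibition and higher numbers for weaker inhibition), gives 19400 nM.
Compound 2, `Cc1cccc(-n2cc(CNC(=O)c3cccc4c3cnn4C(C)C)nn2)c1`, in this assay gives 32300 nM.

Both numbers are high, which on this read-out means weak inhibition of cell growth. Of the two, the number of compound 2 is the larger, but the gap to compound 1 falls within the usual scatter of repeated measurements, so the two compounds cannot be told apart, and neither can be called the weaker one.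

The next compound, compound 3, `CC(C)n1ncc2c(C(=O)NCc3cn(Cc4ccc(C#N)cc4)nn3)cccc21`, keeps everything of compound 2 except one group: 4-cyanobenzyl in place of 3-methylphenyl on an aromatic nitrogen. Going by the values given here, no pair of measured compounds shows what such a swap does on this cell read-out, so there is nothing to anchor a direction.

Among the compounds with values here, with no measured step to go on, the step expected in this assay from compound 2 to compound 3 is a 1.1-fold lower number from compound 2 to compound 3 (0.03 log units; within the scatter), that is, none beyond the scatter. Compound 3 is therefore estimated at 30000 nM, with a plausible range from 10000 nM to 90000 nM.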

Compound 3, half-maximal inhibitory concentration: 18200 nM
The estimate for compound 3 lay 1.6-fold (0.22 log units) above the measured number; measured number inside the range.
By their numbers in this assay, from the lowest: compounds 3, 1 and 2 (each within the scatter of the next).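

In this assay, putting 4-cyanobenzyl in place of 3-methylphenyl on the aromatic nitrogen gives a 1.8-fold lower number from compound 2 to compound 3 (0.25 log units; within the scatter), a step within the scatter. Going by these compounds alone, this is the first measured change at this position, and it shows that the read-out does not separate these two groups, even though 4-cyanobenzyl has more heavy atoms and adds a hydrogen-bond acceptor that 3-methylphenyl lacks. No independent measurement bears on why the two compounds cannot be told apart.

The two groups differ in more than one feature, so this single step cannot show what the nitrile or the benzyl part contributes alone, and a flat result for this pair says little about the position in general. From the compounds shown here alone, it also remains open whether a quite different group on this nitrogen, such as a primary amine, a carboxylic acid or a longer carbon chain, would shift the number beyond the scatter in either direction.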